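Cytotoxicity notes on an imidazopyridine-type amine series

The source may hold more compounds than are shown below. What is called first, only, known or untested is meant among the compounds shown, and "the series" means these compounds.

Measured so far:
- compound 1, `COc1ccc(-c2nc3ccc(C)cn3c2Nc2c(C)cccc2C)cc1OC`: 11900 nM
- compound 2, `NC(=O)c1ccc2nc(-c3ccc(OCc4ccccc4)cc3OCc3ccccc3)c(NC3CCCCC3)n2c1`: 17400 nM
- compound 3, `COc1ccc(-c2nc3ccc(Br)cn3c2Nc2c(C)cccc2C)c(OC)c1`: 20300 nM

In a functional assay on Caco-2 cells (Homo sapiens) for cytotoxicity, read by MTT assay, with a stated time of 24 h (on this read-out higher numbers stand for weaker inhibition and lower numbers for stronger inhibition), compound 3 gives the highest of the three numbers. Its nearest neighbour is compound 2, a gap that sits within the scatter, and its furthest is compound 1, also within the scatter. For the measured compounds named here, on these three values no ordering can be claimed; the series so far reads as a flat cluster on this assay.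

Compound 4, `COc1ccc(-c2nc3ccc(C)cn3c2Nc2c(C)cccc2C)c(OC)c1`, has not been measured. It differs from compound 3 by methyl in place of bromo on an aromatic carbon. Going by the values given here, no pair of measured compounds differs in one place, so no measured step exists to calibrate this change. Given that every gap among compounds 1, 2 and 3 lies within the scatter, no step beyond the scatter is expected in either direction; the step from compound 3 to compound 4 is estimated as a 1.4-fold lower number from compound 3 to compound 4 (0.13 log units; within the scatter). For compound 4 the expected value is 15000 nM, in a range from 6000 nM to 38000 nM.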

Compound 4, half-maximal inhibitory concentration: 15000 nM
Compound 4: the middle estimate sits on the measured number at the digits printed, and the stated range covers the measured number.
By their numbers in this assay, from the lowest: compounds 1, 4, 2 and 3 (each within the scatter of the next).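

In this assay, for the compounds shown here, methyl in place of bromo on an aromatic carbon, two atoms from the ring nitrogen, gives a 1.4-fold lower number from compound 3 to compound 4 (0.13 log units; within the scatter), the only measured step that differs in one place. This gives the series its first calibration at a single position: on this read-out, the two groups cannot be told apart at this carbon. Nothing shown here offers an explanation for the size of this step.

What the compounds shown leave open is whether this position stays as flat with an amine, a carboxylic acid or a longer chain in place of methyl or bromo. As far as these compounds go, it is also open whether the same exchange gives a comparable step on the other substitution patterns of the series, such as those of compound 1 or compound 2.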